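The source may hold more compounds than are shown below. What is called first, only, known or untested is meant among the compounds shown, and "the series" means these compounds.

Of the compounds shown here, three sharing one core have been measured in an ADME assay on isolated protein for inhibition of Amine oxidase [flavin-containing] A (Homo sapiens), read by fluorescence and Amplex Red, with stated times of 15 min and 20 min; on this read-out higher numbers stand for weaker inhibition and lower numbers for stronger inhibition. Compound 1 `C#CCN(CCCOc1ccc2ccc(=O)oc2c1)Cc1ccc(OC)cc1` gives 60000 nM. Within the data shown here, compound 3 `C#CCN(CCCOc1ccc2ccc(=O)oc2c1)Cc1ccc(C(C)C)cc1` gives 77400 nM, and the only single-point step among them, a 1.3-fold higher number from compound 1 to compound 3 (0.11 log units; within the scatter), is small. Compound 2 `C#CCN(CCCCOc1ccc2ccc(=O)oc2c1)Cc1cccc(F)c1` gives 69200 nM and stands second highest of the three, though all three numbers lie within the scatter of one another. Compound 4 `C#CCN(C)CCCCOc1ccc2ccc(=O)oc2c1` differs from compound 2 by hydrogen in place of 3-fluorophenyl on a saturated chain carbon bound to an amine nitrogen. Among the measured compounds shown here, none of the measured steps bears on this change: the one measured step swaps a group on an aromatic carbon, whereas here the whole 3-fluorophenyl leaves. For the measured compounds named here, with no comparable step, a number near that of compound 2 is expected in this assay, with a wide range; the expected step is a 1.2-fold higher number from compound 2 to compound 4 (0.06 log units; within the scatter). Compound 4 is estimated at 80000 nM, between 20000 nM and 300000 nM.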

Compound 4, half-maximal inhibitory concentration: 3280 nM
The estimate for compound 4 lay 24-fold (1.39 log units) above the measured number; measured number outside the range, below it.
By their numbers in this assay, from the lowest: compound 4; then compounds 1, 2 and 3 (each within the scatter of the next).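

Replacing 3-fluorobenzyl with methyl in this assay gives a 21-fold lower number from compound 2 to compound 4 (1.32 log units; beyond the scatter) and so separates compound 4 from the other compounds. The earlier compounds shown here all kept a substituted benzyl group and stayed within the scatter of one another, so they gave no sign that this place could move the number so far. Nothing measured here explains the step.

On these data alone, whether an ethyl or an unsubstituted benzyl group in that place would give a number nearer compound 4 or compound 2 stays open. So does whether methyl has the same effect on the shorter chain of compound 1.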